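The source may hold more compounds than are shown below. What is called first, only, known or untested is meant among the compounds shown, and "the series" means these compounds.

Working notes on the series. In a functional assay on HCT-116 cells (Homo sapiens) for inhibition, read by MTT assay, with a stated time of 72 h (on this read-out higher numbers stand for weaker inhibition and lower numbers for stronger inhibition), compound 1 (`COc1cc2c(Oc3ccc(NC(=O)c4nn(-c5ccccc5C)cc(C)c4=O)c(F)c3)ccnc2cc1OCCCCCCC(=O)NO`) gives 2300 nM and compound 3 (`COc1cc2c(Oc3ccc(NC(=O)c4nn(-c5ccccc5C)cc(C)c4=O)cc3)ccnc2cc1OCCCCCC(=O)NO`) gives 290 nM as measured numbers. Compound 2 (`COc1cc2c(Oc3ccc(NC(=O)c4nn(-c5ccc(F)c(Cl)c5)cc(C)c4=O)cc3)ccnc2cc1OCCCCCCC(=O)NO`) gives 370 nM and so stands within the scatter of compound 3. Its number lies beyond the scatter from that of compound 1, the furthest of the three.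

Within the data shown here, no two measured compounds differ in one place only, so no measured step isolates the group on the aromatic nitrogen. Compound 4 (`COc1cc2c(Oc3ccc(NC(=O)c4nn(-c5cccc(C)c5)cc(C)c4=O)cc3)ccnc2cc1OCCCCCCC(=O)NO`) is compound 2 with that group exchanged. The change is 3-methylphenyl in place of 3-chloro-4-fluorophenyl on an aromatic nitrogen with 3-methylphenyl in place of 3-chloro-4-fluorophenyl on an aromatic nitrogen, next to the ring nitrogen.

Among the measured compounds shown here, the only indirect guide is weak: compound 2 at 370 nM and compound 3 at 290 nM carry different groups on that nitrogen, and their chains also differ, yet their values lie within the scatter of each other. No step beyond the scatter is therefore expected in this assay for this exchange, and the estimated change is a 1.1-fold lower number from compound 2 to compound 4 (0.02 log units; within the scatter) with no firm direction. The estimated value for compound 4 is 350 nM within an expected range from 130 nM to 950 nM on this read-out.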

Compound 4, half-maximal inhibitory concentration: 370 nM
Compound 4: the middle estimate sits 1.1-fold (0.02 log units) below what was measured; low and high end bracket the measured number.
By their numbers in this assay, from the lowest: compounds 3, 2 and 4 (each within the scatter of the next); then compound 1.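

In this assay, among these compounds, the exchange to 3-methylphenyl in place of 3-chloro-4-fluorophenyl on the aromatic nitrogen gives no change at the digits printed from compound 2 to compound 4 (within the scatter), and this is the only measured step that isolates the group at this position. On this chain and core, a phenyl group carrying a single methyl group and no halogen therefore reads the same as one carrying chlorine and fluorine, although the group goes from 8 heavy atoms to 7 and neither group has a hydrogen-bond donor, acceptor or net charge. Nothing measured here accounts for this flat step.

The compounds shown leave open whether this position also tolerates a group of a different kind, such as an amine or a carboxylic acid on the phenyl ring, or a saturated ring such as cyclohexyl in place of the phenyl ring. Among the compounds shown here, it also remains open whether the same exchange stays flat with the shorter chain of compound 3 or the added fluorine of compound 1, as no measured pair isolates either of those changes.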